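The source may hold more compounds than are shown below. What is called first, only, known or untested is meant among the compounds shown, and "the series" means these compounds.

Measured so far:
- compound 1 `CCCCNc1nc(NCC)c2cc(OC)c(OC)cc2n1`: 5290 nM
- compound 2 `COc1cc2nc(N3CCCC3)nc(N)c2cc1OC`: 28200 nM

In an ADME assay on L6 cells (Rattus norvegicus) for cytotoxicity, read by fluorescence and resazurin assay, with a stated time of 70 h (on this read-out higher numbers stand for weaker inhibition and lower numbers for stronger inhibition), compound 2 stands highest of the two at 28200 nM, and compound 1 gives 5290 nM. The gap between these two numbers lies beyond the scatter. Compound 3 `COc1cc2nc(N3CCCC3)nc(N3CCCC3)c2cc1OC` places pyrrolidin-1-yl in place of amino on an aromatic carbon. Among the measured compounds shown here, no measured pair isolates this change, so the only guide is the lower value of compound 1 at 5290 nM. A moderate move toward a lower number in this assay is expected, with the expected step being a 2.6-fold lower number from compound 2 to compound 3 (0.41 log units; beyond the scatter). For compound 3 the estimated value is 11000 nM, with an expected range of 3500 nM to 32000 nM.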

Compound 3, half-maximal inhibitory concentration: 3960 nM
Compound 3: the middle estimate sits 2.8-fold (0.44 log units) above what was measured; the measured number falls inside the stated range.
By their numbers in this assay, from the lowest: compounds 3 and 1 (each within the scatter of the next); then compound 2.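

In this assay, among the compounds shown here, pyrrolidin-1-yl in place of amino on an aromatic carbon next to the ring nitrogen gives a 7.1-fold lower number from compound 2 to compound 3 (0.85 log units; beyond the scatter) and so provides the first single-place comparison. The step cannot be divided between the loss of the amino group and the arrival of the five-membered ring. No evidence bears on its cause. As far as these compounds go, whether piperidine, morpholine or dimethylamino at this carbon would give a step of similar size remains open. From the compounds shown here alone, the effect of replacing the pyrrolidin-1-yl group that compound 2 and compound 3 share also remains open.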